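Fluoro on the chlorophenyl of compound 2: notes

The compounds below may be only part of what the source reports. "The series", "measured", "known", "first", "only" and "open" are said of these compounds alone.

Measured so far, in an assay on isolated protein for positive allosteric modulation of Neuronal acetylcholine receptor; alpha4/beta2 (Homo sapiens); a higher number here means that more compound is needed for the effect, a lower number that less compound is needed:
- compound 1 `CN(Cc1cc(-c2ccccc2Cl)no1)C(=O)C1CCNCC1` gives 350 nM
- compound 2 `Clc1ccccc1-c1cc(-c2cnn(C3CCNCC3)c2)on1` gives 120 nM
- compound 3 `Cc1c(-c2cc(-c3ccccc3Cl)no2)cnn1C1CCNCC1` gives 18 nM

Compound 2 stands second highest of the three numbers in this assay. Compound 1 sits nearest, and its number is higher; compound 3 sits furthest, with the lower number. Within the data shown here, the only step between compounds that differ in one place is a 6.7-fold lower number from compound 2 to compound 3 (0.82 log units; beyond the scatter), a methyl in place of hydrogen on an aromatic carbon of the shared core.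

Compound 4 `Fc1cccc(Cl)c1-c1cc(-c2cnn(C3CCNCC3)c2)on1` differs from compound 2 by fluoro in place of hydrogen on an aromatic carbon. Among the measured compounds shown here, no measured step touches the 2-chlorophenyl; the one measured step concerns a different ring, so it does not bear directly on this change. Without a comparable step, the change from compound 2 is expected to leave this assay near its starting point. The step of no change at the digits printed from compound 2 to compound 4 (within the scatter) is therefore expected to stay within the scatter. For compound 4 the expected value is 120 nM, with a range from 45 nM to 320 nM.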

Compound 4, half-maximal effective concentration: 48 nM
For compound 4 the middle estimate is 2.5-fold (0.40 log units) above the measured one; the range from low to high includes it.
By their numbers in this assay, from the lowest: compound 3; then compound 4; then compound 2; then compound 1.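

With a 2.5-fold lower number from compound 2 to compound 4 (0.40 log units; beyond the scatter) in this assay as the first measured step on the 2-chlorophenyl, this ring is shown to respond to substitution: fluoro on an aromatic carbon, ortho to a large group and meta to a chloro group, moves the number beyond the scatter. Alongside a 6.7-fold lower number from compound 2 to compound 3 (0.82 log units; beyond the scatter) on a different ring, this means that the number of compound 2 can be lowered by a change in either of two separate places. No measurement shown here accounts for the effect of the fluoro group.

Going by these compounds, whether a methoxy or a trifluoromethyl group on the same carbon would act as fluoro does remains open. Also open, on these data alone, is whether the fluoro of compound 4 and the methyl of compound 3 would add up within one compound.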